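The compounds below may be only part of what the source reports. "The series", "measured", "known", "first", "only" and "open" are said of these compounds alone.

Compound 1 `CNS(=O)(=O)c1ccc(-c2cnc(N)c(-c3ccc(OC)nc3)c2)cc1` gives 12.5 ug/mL in a physicochemical assay for solubility, read by nephelometry, in phosphate buffer, measured as kinetic solubility, at pH 6.5; on this read-out lower numbers stand for lower solubility and higher numbers for higher solubility.
Compound 2 `COc1ccc(-c2cc(-c3ccc(C(F)(F)F)cc3)cnc2N)cn1` gives 1.6 ug/mL in this assay.
Compound 3 `COc1ccc(-c2cc(-c3cccc(C(N)=O)c3)cnc2N)cn1` gives 12.5 ug/mL in this assay.

Compound 1 stands level with compound 3 at the digits shown; the two are within the scatter of each other and together sit at the top of the three numbers. Compound 2 is the furthest from compound 1, with a 7.8-fold lower number from compound 1 to compound 2 (0.89 log units; beyond the scatter).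

Compound 4 `CNC(=O)c1ccc(-c2cnc(N)c(-c3ccc(OC)nc3)c2)cc1` has not yet been measured in this assay. It differs from compound 1 in one place: methylcarbamoyl in place of methylsulfamoyl on an aromatic carbon. For the measured compounds named here, the only measured step that starts from compound 1 is the one to compound 2, where trifluoromethyl took the place of methylsulfamoyl, and that step was large. The present change keeps a hydrogen-bond donor and a hydrogen-bond acceptor in the group that enters, which the step to compound 2 did not, and compound 3, which carries a carbamoyl group, shows the same number as compound 1. A step no larger than the scatter is therefore expected, with a slight lean downward. Compound 4 is estimated to give 10 ug/mL, between 4 ug/mL and 25 ug/mL, meaning an expected step of a 1.3-fold lower number from compound 1 to compound 4 (0.10 log units; within the scatter).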

Compound 4, solubility: 50 ug/mL
Compound 4: the middle estimate sits 5.0-fold (0.70 log units) below what was measured; the whole stated range lies below it.
By their numbers in this assay, from the lowest: compound 2; then compounds 1 and 3 (each within the scatter of the next); then compound 4.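

In this assay, for the compounds shown here, replacing methylsulfamoyl with methylcarbamoyl gives a 4.0-fold higher number from compound 1 to compound 4 (0.60 log units; beyond the scatter) and so shows that a change at this place, on an aromatic carbon para to a large group, can raise the number as well as lower it; until now the only step here was the fall of a 7.8-fold lower number from compound 1 to compound 2 (0.89 log units; beyond the scatter) when trifluoromethyl entered. Methylsulfamoyl and methylcarbamoyl each count 1 hydrogen-bond donor, so a shared donor count did not keep these two compounds together, and the three groups now tried at this place span a 31-fold higher number from compound 2 to compound 4 (1.49 log units; beyond the scatter) in all. Nothing measured here gives a reason for the rise from methylsulfamoyl to methylcarbamoyl.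

The compounds shown leave open where a carboxylic acid, a simple amine or a longer chain on the amide nitrogen would fall at this place, and so whether methylcarbamoyl is near the top of what this position can give or only the best of three groups. On these data alone, compounds 1, 2 and 4 also share one core, so whether the same swap gives a similar rise on a different core remains unknown.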